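This account rests on a few compounds, and the source may have more. Where it says the series, first, only, none or still open, it means among the compounds named here.

Measured so far in the series:
- compound 1, `CN(C)CCC(OC(=O)Nc1ccc(C(F)(F)F)cc1)c1ccc(Cl)cc1`, gives 94% in an assay on NIH3T3 cells with Urotensin-2 receptor (Homo sapiens) as the target; on this read-out lower numbers stand for smaller maximal responses and higher numbers for larger maximal responses
- compound 2, `CN(C)CCC(OC(=O)Nc1ccc(-c2ccccc2)cc1)c1ccc(Cl)cc1`, gives 58% in this assay

Compound 2 holds the lowest of the two numbers; the nearest is compound 1, and the step between them is a number 36 percentage points lower from compound 1 to compound 2 (beyond the scatter), well beyond the scatter. Compound 3, `CN(C)CCC(OC(=O)Nc1ccc(C(C)(C)C)cc1)c1ccc(Cl)cc1`, is not yet measured. Its change from compound 2 is tert-butyl in place of phenyl on an aromatic carbon.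

Among the compounds with values here, only one measured step bears on this change, the one from compound 1 to compound 2, in which phenyl entered at the same aromatic carbon and the maximal response fell by a number 36 percentage points lower from compound 1 to compound 2 (beyond the scatter). Within the data shown here, in compound 3 the phenyl leaves again, but what enters is tert-butyl rather than the trifluoromethyl of compound 1, so no measured pair shows the exact substitution. The expectation is a step back upward, a number 22 percentage points higher from compound 2 to compound 3 (beyond the scatter), as phenyl leaves, though probably not a full return to the level of compound 1. For compound 3 the estimated maximal response in this assay is 80%, with a range from 55% to 100%.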

Compound 3, largest response reached (reported as efficacy), in percent of the reference or control that the assay uses: 105%
The estimate for compound 3 lay 25 percentage points below the measured number; the measured number lies above the stated range.
By their numbers in this assay, from the lowest: compound 2; then compound 1; then compound 3.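

At this aromatic carbon, tert-butyl in place of phenyl gives a number 47 percentage points higher from compound 2 to compound 3 (beyond the scatter) in this assay, a rise that exceeds the earlier fall of a number 36 percentage points lower from compound 1 to compound 2 (beyond the scatter), so the loss seen in compound 2 does not persist once phenyl is gone. Tert-butyl in place of trifluoromethyl gives a number 11 percentage points higher from compound 1 to compound 3 (beyond the scatter), which shows that the maximal response at this carbon can go above the level of compound 1 and leaves phenyl as the only one of the three groups with a number lower than the other two. No measurement available here accounts for this order of the three groups.

The three compounds leave open whether the low number of compound 2 goes with the aromatic ring or with the larger heavy-atom count of phenyl, as the two groups differ in both; cyclohexyl, a carbon ring that is not aromatic, would separate the two. Also open, from the compounds shown here alone, is how a group such as an amine or a carboxylic acid at this carbon would behave, as all three groups here have no hydrogen-bond donors or acceptors counted for the phenyl and tert-butyl pair.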